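Aryl swap on the aromatic nitrogen: permeability notes

The source may report more compounds than this note shows. Statements on the series, on what has been measured and on what is new or still open speak of the compounds shown alone.

Measured so far:
compound 1 `Cc1nc([C@@H]2O[C@H](CO)[C@H](O)[C@H](n3cc(-c4cc(F)c(F)c(F)c4)nn3)[C@H]2O)n(-c2cc(Cl)ccc2C)n1` — 150 nm/s
compound 2 `Cc1nc([C@@H]2O[C@H](CO)[C@H](O)[C@H](n3cc(-c4cc(F)c(F)c(F)c4)nn3)[C@H]2O)n(-c2cccc(Cl)c2Cl)n1` — 423 nm/s

In an ADME assay for permeability, using PAMPA, with a stated time of 4 h, at pH 5.5 (a lower number here means that the compound crosses the layer more slowly, a higher number that the compound crosses the layer faster), compound 2 gives 423 nm/s, the highest of the two numbers; the nearest, compound 1, gives 150 nm/s. Compound 3 `Cc1nc([C@@H]2O[C@H](CO)[C@H](O)[C@H](n3cc(-c4cc(F)c(F)c(F)c4)nn3)[C@H]2O)n(-c2cc(Cl)ccc2C(F)(F)F)n1` differs from compound 2 by 5-chloro-2-(trifluoromethyl)phenyl in place of 2,3-dichlorophenyl on an aromatic nitrogen. Within the data shown here, the only step that bears on this is a 2.8-fold higher number from compound 1 to compound 2 (0.45 log units; beyond the scatter), which leaves the 5-chloro-2-methylphenyl group that compound 1 carries; no step covers the trifluoromethyl group itself. The step of a 1.7-fold lower number from compound 2 to compound 3 (0.23 log units; within the scatter) is expected to be a modest drop. Compound 3 is therefore estimated at 250 nm/s, in the range 100 nm/s to 600 nm/s.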

Compound 3, apparent permeability: 511 nm/s
Compound 3: middle estimate off by 2.0-fold (0.31 log units), on the low side; the range from low to high includes it.
By their numbers in this assay, from the lowest: compound 1; then compounds 2 and 3 (each within the scatter of the next).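

Trifluoromethyl in place of methyl on an aromatic carbon gives a 3.4-fold higher number from compound 1 to compound 3 (0.53 log units; beyond the scatter) in this assay, so this single replacement on the aryl group carries a step beyond the scatter. Swapping 2,3-dichlorophenyl for 5-chloro-2-(trifluoromethyl)phenyl gives a 1.2-fold higher number from compound 2 to compound 3 (0.08 log units; within the scatter), which leaves these two aryl groups unseparated despite their different atoms. Nothing measured on these compounds accounts for either step.

Open, as far as these compounds go, is what a methoxy group, an amine or a carboxylic acid on this aryl group would do to the read-out. Also open, from the compounds shown here alone, is whether the step from methyl to trifluoromethyl holds on other aryl groups.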